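A Fluorophenyl Swap on the Ring Nitrogen

The compounds below may be only part of what the source reports. "The series", "measured", "known", "first", "only" and "open" are said of these compounds alone.

Three compounds have been measured in a physicochemical assay for solubility, read by turbidimetry, measured as kinetic solubility, at pH 6.8; a higher number here means a more soluble compound, a lower number a less soluble compound:
Compound 1 `O=C(NCCCCc1ccccc1)c1cccc(C2SCC(=O)N2c2ccccn2)c1` gives 20000 nM.
Compound 2 `C#Cc1cccc(N2C(=O)CSC2c2cccc(C(=O)NCCCCc3ccccc3)c2)c1` gives 10000 nM.
Compound 3 `Cc1cccc(N2C(=O)CSC2c2cccc(C(=O)NCCCCc3ccccc3)c2)c1` gives 10000 nM.

Compound 3 sits level with compound 2, the two together the lowest of the three numbers, with no change at the digits printed from compound 2 to compound 3 (within the scatter) and a 2.0-fold lower number from compound 1 to compound 3 (0.30 log units; within the scatter). All three compounds share one core and differ only in the group on the amide-type nitrogen in the ring. Compound 4 `O=C(NCCCCc1ccccc1)c1cccc(C2SCC(=O)N2c2ccccc2F)c1` continues that series: 2-fluorophenyl in place of 3-methylphenyl on an amide-type nitrogen in a ring. Among the measured compounds shown here, the steps that bear on it, a 2.0-fold lower number from compound 1 to compound 2 (0.30 log units; within the scatter), a 2.0-fold lower number from compound 1 to compound 3 (0.30 log units; within the scatter) and no change at the digits printed from compound 2 to compound 3 (within the scatter), all stay within the scatter, so no step beyond the scatter is expected. The expected step is a 1.2-fold higher number from compound 3 to compound 4 (0.08 log units; within the scatter). In this assay compound 4 is estimated to give 12000 nM, within 5000 nM to 25000 nM.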

Compound 4, solubility: 20000 nM
For compound 4 the middle estimate is 1.7-fold (0.22 log units) below the measured one; the range from low to high includes it.
By their numbers in this assay, from the lowest: compounds 2, 3, 1 and 4 (each within the scatter of the next).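

Placing 2-fluorophenyl on the amide-type nitrogen in the ring gives a 2.0-fold higher number from compound 3 to compound 4 (0.30 log units; within the scatter) and a 2.0-fold higher number from compound 2 to compound 4 (0.30 log units; within the scatter) and also no change at the digits printed from compound 1 to compound 4 (within the scatter) in this assay. Among the compounds shown here, with a fluorine-bearing ring now included, all four groups tried at this position remain within the scatter of one another, so a fluorine on the aromatic ring adds no separable step here. No measured evidence is available to explain these numbers.

As far as these compounds go, whether a group carrying an amine or a carboxylic acid at this position would give a step beyond the scatter stays open.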